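This account rests on a few compounds, and the source may have more. Where it says the series, first, only, none or still open, it means among the compounds named here.

Working notes on the shared core of compound 3 `COc1cc(-c2ccnc3cc(-c4ccccc4)nn23)cc(OC)c1OC`. Among the compounds with values here, in a functional assay on A549 cells (Homo sapiens) for inhibition, read by CCK-8 assay, with a stated time of 48 h (on this read-out lower numbers stand for stronger inhibition and higher numbers for weaker inhibition), compound 3 gives 208 nM, the second highest of the three numbers measured so far. Compound 1 `COc1cc(-c2ccnc3cc(-c4ccc(C)cc4)nn23)cc(OC)c1OC` gives 3 nM, and compound 2 `COc1ccc(-c2cc3nccc(-c4cc(OC)c(OC)c(OC)c4)n3n2)cc1F` gives 545 nM. The measured steps are a 69-fold higher number from compound 1 to compound 3 (1.84 log units; beyond the scatter), a 180-fold higher number from compound 1 to compound 2 (2.26 log units; beyond the scatter) and a 2.6-fold lower number from compound 2 to compound 3 (0.42 log units; beyond the scatter). Compound 4 `COc1cc(-c2ccnc3cc(-c4cccc(C)c4)nn23)cc(OC)c1OC` differs from compound 3 by methyl in place of hydrogen on an aromatic carbon, the methyl entering on an aromatic carbon of the six-membered carbon-only ring, meta to a large group; in compound 1 the methyl of that ring does not stand meta to the large group. The step of a 69-fold higher number from compound 1 to compound 3 (1.84 log units; beyond the scatter) bears on this change directly when read in reverse, and it is large; whether a methyl placed meta to a large group repeats it cannot be told from the three compounds, since none of them carries a methyl at that place. A lower number is therefore expected for compound 4, though by less than the full reversal. The step expected for compound 4 is estimated as a 5.2-fold lower number from compound 3 to compound 4 (0.72 log units; beyond the scatter). Compound 4 is estimated at 40 nM, with a range from 6 nM to 250 nM.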

Compound 4, half-maximal inhibitory concentration: 5730 nM
Compound 4: middle estimate off by 140-fold (2.16 log units), on the low side, and the stated range ends below it.
By their numbers in this assay, from the lowest: compound 1; then compound 3; then compound 2; then compound 4.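

In this assay, methyl on the six-membered carbon-only ring does not have one effect across the ring: meta to a large group it gives a 28-fold higher number from compound 3 to compound 4 (1.44 log units; beyond the scatter), while removing the methyl of compound 1, which does not stand meta to the large group, gives a 69-fold higher number from compound 1 to compound 3 (1.84 log units; beyond the scatter). The place of the methyl alone separates the two methylated compounds, with a 1900-fold higher number from compound 1 to compound 4 (3.28 log units; beyond the scatter), and 3-methylphenyl also ends above 3-fluoro-4-methoxyphenyl, with an 11-fold higher number from compound 2 to compound 4 (1.02 log units; beyond the scatter). Nothing measured here bears on the cause of this reversal.

Within the data shown here, with methyl as the only group at this place, it remains open whether methoxy, chlorine or an amine there would repeat the step from hydrogen to methyl. Going by these compounds, it also remains open whether the opposite directions of the two methyl steps would hold on any other core.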